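The compounds below may be only part of what the source reports. "The series", "measured", "known", "first", "only" and "open" are said of these compounds alone.

Of the compounds shown here, three have been tested so far in a functional assay on CWR22R cells (Homo sapiens) for antiproliferative activity, read by propidium iodide staining, with a stated time of 96 h; on this read-out lower numbers stand for stronger inhibition and higher numbers for weaker inhibition. There, compound 1 `CC(O)(CSc1ccc(S(F)(F)(F)(F)F)cc1)C(=O)Nc1cccc(S(F)(F)(F)(F)F)c1` gives 13100 nM and compound 2 `CC(O)(COc1cccc(S(F)(F)(F)(F)F)c1)C(=O)Nc1cc(C(F)(F)F)cc(C(F)(F)F)c1` gives 2300 nM. Compound 3 `CC(O)(CS(=O)(=O)c1ccc(S(F)(F)(F)(F)F)cc1)C(=O)Nc1cccc(S(F)(F)(F)(F)F)c1` gives 12300 nM, which lies within the usual scatter of repeated measurements of the value for compound 1. The number for compound 3 is clearly higher than that for compound 2, so compound 3 is the weaker inhibitor of that pair.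

The next compound to be tested is compound 4 `CC(O)(CS(=O)(=O)c1ccc(OC(F)(F)F)cc1)C(=O)Nc1cccc(S(F)(F)(F)(F)F)c1`. It keeps everything in compound 3 except one group, and this makes the comparison a clean one. On an aromatic carbon of a six-membered aromatic ring of carbon only, para to a large group, trifluoromethoxy enters in place of a group of 5 fluorine and 1 sulfur (a group of 5 heavy atoms (1 carbon, 1 oxygen, 3 fluorine; no ring) in place of a group of 6 heavy atoms (5 fluorine, 1 sulfur; no ring), on an aromatic carbon).

Going by the values given here, the compounds measured so far include no single-place step that could serve as a guide, so any forecast here is loose. With no such evidence pointing either way, only a small change is expected, with no firm direction. The expected change, a 1.2-fold lower number from compound 3 to compound 4 (0.09 log units; within the scatter), would stay within the usual scatter. The estimate for compound 4 is 10000 nM, with an estimated range of 4000 nM to 25000 nM.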

Compound 4, half-maximal inhibitory concentration: 31200 nM
The estimate for compound 4 lay 3.1-fold (0.49 log units) below the measured number; measured number outside the range, above it.
By their numbers in this assay, from the lowest: compound 2; then compounds 3 and 1 (each within the scatter of the next); then compound 4.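

In this assay this is the first comparison among the compounds shown that changes a single place, and it gives a 2.5-fold higher number from compound 3 to compound 4 (0.40 log units; beyond the scatter) as a modest step beyond the usual scatter. It shows that this position, on an aromatic carbon of a six-membered aromatic ring of carbon only and para to a large group, is not indifferent to what it carries: trifluoromethoxy is no like-for-like stand-in for the group of 5 fluorine and 1 sulfur, and the exchange weakens inhibition while the rest of the molecule stays the same. Nothing available on these compounds accounts for this shift, so its cause remains unknown.

This single pair cannot tell whether the same exchange would weaken inhibition on the core of compound 1, with its different link, or on that of compound 2, with its different amide side. Also open, on these data alone, is how this position would respond to quite different groups, such as a nitrile, an amine or a carboxylic acid, or to a bare hydrogen.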